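One Group Changes: From Compound 3 to Compound 4

The source may report more compounds than this note shows. Statements on the series, on what has been measured and on what is new or still open speak of the compounds shown alone.

Compound 1 `N#Cc1ccc(-c2nccnc2OC2CN(c3ccc4ccccc4n3)C2)cc1` gives < 1000 nM (a limit of the assay, not a number)
Compound 2 `c1ccc2nc(N3CC(Oc4nccnc4-c4ccncc4)C3)ccc2c1` gives 56000 nM (measured)
Compound 3 `Cc1ncccc1-c1nccnc1OC1CN(c2ccc3ccccc3n2)C1` gives 253000 nM (measured)

These three compounds share a core and differ only in one group, and all were tested in a physicochemical assay for solubility, in phosphate buffer, at pH 7.4; on this read-out lower numbers stand for lower solubility and higher numbers for higher solubility (the read-out used throughout). Compound 3 has 253000 nM as the highest of the two actual numbers. Its nearest neighbour is compound 2, as the step of a 4.5-fold higher number from compound 2 to compound 3 (0.65 log units; beyond the scatter) shows. Compound 1 offers only a limit at < 1000 nM and not a number.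

Compound 4 `COC(=O)N1CCC(c2nccnc2OC2CN(c3ccc4ccccc4n3)C2)CC1` carries 1-(methoxycarbonyl)piperidin-4-yl in place of 2-methylpyridin-3-yl on an aromatic carbon and so brings a six-membered non-aromatic ring to this spot. The measured changes of this group gave an at least 56-fold higher number from compound 1 to compound 2 (1.74 log units; beyond the scatter) and an at least 250-fold higher number from compound 1 to compound 3 (2.40 log units; beyond the scatter) as large steps, and a 4.5-fold higher number from compound 2 to compound 3 (0.65 log units; beyond the scatter) as a modest one. Each of them exchanged one aromatic ring for another, so none tests a non-aromatic ring directly. They do show that this group can move the read-out widely. Compound 3 already sits at the top with 253000 nM so a fall is the likelier direction. The expected change is an 8.4-fold lower number from compound 3 to compound 4 (0.93 log units; beyond the scatter) which would be a modest to large step towards a lower number. Compound 4 is estimated at 30000 nM with 4000 nM to 150000 nM as the expected range.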

Compound 4, solubility: 138000 nM
For compound 4 the middle estimate is 4.6-fold (0.66 log units) below the measured one; the measured number falls inside the stated range.
By their numbers in this assay, from the lowest: compound 2; then compounds 4 and 3 (each within the scatter of the next). At a limit, below all of these: compound 1.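

In this assay, compound 4 shows that a non-aromatic ring on this carbon, next to the ring nitrogen, can give a number that cannot be told apart from that of the best aromatic group shown, since a 1.8-fold lower number from compound 3 to compound 4 (0.26 log units; within the scatter) leaves 1-(methoxycarbonyl)piperidin-4-yl and 2-methylpyridin-3-yl level here. The same group still stands clear of pyridin-4-yl, with a 2.5-fold higher number from compound 2 to compound 4 (0.39 log units; beyond the scatter), so an aromatic ring at this spot is not needed for a number in this upper range, and the earlier aromatic-for-aromatic exchanges could not show that. The large step of an at least 130-fold higher number from compound 1 to compound 4 (2.13 log units; beyond the scatter) starts from a limit of the assay in compound 1, not from a number, so its true size stays unknown: the limit of < 1000 nM in this assay, at which 1 of the 4 values shown sits.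

The compounds shown leave open whether the piperidine ring or its methoxycarbonyl group sets this number, a question that a free piperidine amine or a plain cyclohexyl ring at the same carbon would help to separate. They also leave open how a carboxylic acid or a small open chain would read at this position.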